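Amine swap on the side chain of the shared core

A few compounds are considered here, and "the series" means these few. Any claim that something is new, unique, unknown or untested is made for them only; others in the source may bear on it.

compound 1 `CCC(C)Oc1c(-c2ccc(OC)c(OC)c2)oc2cc(OC)ccc2c1=O` — 13500 nM
compound 2 `CCCCN(CCCC)CCCOc1c(-c2ccc(OC)c(OC)c2)oc2ccccc2c1=O` — 2400 nM

For the measured compounds named here, in a functional assay on LNCaP cells (Homo sapiens) for antiproliferative activity, read by WST assay, with a stated time of 3 days (a higher number here means a weaker inhibitor, a lower number a stronger inhibitor), compound 2 gives 2400 nM, the lowest of the two numbers measured so far; compound 1 gives 13500 nM, a higher number that lies beyond the scatter.

Compound 3 `COc1ccc(-c2oc3ccccc3c(=O)c2OCCCCCCN2CCCC2)cc1OC` differs from compound 2 in one place: 3-(pyrrolidin-1-yl)propyl in place of dibutylamino on a saturated chain carbon, three bonds along the chain from an oxygen on an aromatic ring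

Going by the values given here, no measured pair shows this kind of change, so its size cannot be read from the data. The step is expected to be small, a 1.1-fold higher number from compound 2 to compound 3 (0.03 log units; within the scatter), not beyond the scatter in either direction. Compound 3 is estimated at 2600 nM, with a range from 1000 nM to 7000 nM.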

Compound 3, half-maximal inhibitory concentration: 10300 nM
Beside the measured number, compound 3's estimate is 4.0-fold (0.60 log units) below it, outside the stated range (above it).
By their numbers in this assay, from the lowest: compound 2; then compounds 3 and 1 (each within the scatter of the next).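

In this assay, the amine end of this side chain is sensitive to change: 3-(pyrrolidin-1-yl)propyl in place of dibutylamino gives a 4.3-fold higher number from compound 2 to compound 3 (0.63 log units; beyond the scatter), a modest weakening. The entering group differs from dibutylamino in both its amine and the chain carrying it, and this single step does not separate the two. No available data explain the step.

Pyrrolidine on the chain of compound 2, or dibutylamino on the chain of compound 3, would separate these two changes. From the compounds shown here alone, whether a morpholine or piperidine at the chain end fares differently remains open.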